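Replacing a tert-butoxy by an amino: compound 4 awaits

The compounds below may be only part of what the source reports. "The series", "measured", "known", "first", "only" and "open" are said of these compounds alone.

Compound 1 `Cc1cc(-c2ccc(F)cc2)c(S(C)(=O)=O)cc1C(=O)N=C(N)N` in a functional assay for inhibition of sodium/hydrogen exchanger (Oryctolagus cuniculus); a lower number here means a stronger inhibitor, a higher number a weaker inhibitor: compound 1 gives 36 nM.
Compound 2 `CCOc1cc(C)c(C(=O)N=C(N)N)cc1S(C)(=O)=O`: compound 2 gives 19 nM.
Compound 3 `Cc1cc(OC(C)(C)C)c(S(C)(=O)=O)cc1C(=O)N=C(N)N`: compound 3 gives 9.4 nM.

Compound 3 has the lowest number of the three, and its lead over the others is beyond the scatter: the step of a 3.8-fold lower number from compound 1 to compound 3 (0.58 log units; beyond the scatter) is modest, and so is a 2.0-fold lower number from compound 2 to compound 3 (0.31 log units; beyond the scatter). The move a 1.9-fold lower number from compound 1 to compound 2 (0.28 log units; within the scatter) lies within the scatter.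

Compound 4 `Cc1cc(N)c(S(C)(=O)=O)cc1C(=O)N=C(N)N` differs from compound 3 in one place: amino in place of tert-butoxy on an aromatic carbon. Among the measured compounds shown here, no measured step swaps an oxygen-linked group for a nitrogen-linked one, so none bears on it directly. The closest guide is the size comparison in a 2.0-fold lower number from compound 2 to compound 3 (0.31 log units; beyond the scatter), where the larger tert-butyl gave the lower number than ethyl; the amino is smaller still, with one heavy atom against five. Going by that trend, which rests on compound 2 and compound 3 only, a higher number for compound 4 is expected, probably larger than the step from compound 2 to compound 3, and the estimate is a 3.7-fold higher number from compound 3 to compound 4 (0.57 log units; beyond the scatter). Compound 4 is therefore expected to give about 35 nM, somewhere between 9 nM and 140 nM.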

Compound 4, half-maximal inhibitory concentration: 16 nM
Estimate against measurement, compound 4: 2.2-fold (0.34 log units) above; low and high end bracket the measured number.
By their numbers in this assay, from the lowest: compounds 3, 4, 2 and 1 (each within the scatter of the next, the first and the last beyond it).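

At this position, ortho to a methylsulfonyl group, the amino group has 1 heavy atom against 5 for tert-butoxy, yet in this assay the change stays within the scatter (a 1.7-fold higher number from compound 3 to compound 4 (0.23 log units; within the scatter)), and the same holds for the swap from ethoxy (a 1.2-fold lower number from compound 2 to compound 4 (0.07 log units; within the scatter)). The earlier gap between compound 2 and compound 3 therefore does not extend into a size trend: compound 4, with the smallest group of the set, goes against it, and heavy-atom count alone does not order these compounds. Only the 4-fluorophenyl group stands apart from amino, in a modest step beyond the scatter (a 2.3-fold lower number from compound 1 to compound 4 (0.35 log units; beyond the scatter)), and nothing shown here accounts for any of these results.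

The compounds shown leave open how a substituted amine such as dimethylamino or a longer chain such as butylamino would read at this position, since the amino group is the only nitrogen-linked group here. They also leave open whether a hydroxyl group, the smallest oxygen-linked counterpart to ethoxy and tert-butoxy, would fall with compound 4 or apart from it.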